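Swapping a Thiazole Ring for an Imidazole Ring

This account rests on a few compounds, and the source may have more. Where it says the series, first, only, none or still open, it means among the compounds named here.

Three measured compounds share one core and differ only in the five-membered ring attached to it. Compound 1 `O=C(O)c1cc(-c2cc[nH]n2)ccc1O` carries a pyrazole, compound 2 `O=C(O)c1cc(-n2ccnc2)ccc1O` an imidazole joined through a ring nitrogen, and compound 3 `O=C(O)c1cc(-c2nccs2)ccc1O` a thiazole. In a functional assay on the whole organism for inhibition, with Rattus norvegicus as the target, read by paw edema (a higher number here means that more compound is needed for the effect, a lower number that less compound is needed), compound 2 gives 75 mg/kg. For compound 1 the value > 250 mg/kg is only a limit of the assay, not a number. For compound 3 the value > 250 mg/kg is likewise only a limit. Compound 3 thus stands at the limit of > 250 mg/kg in this assay, at which 2 of the 3 values shown sit. The step of an at least 3.3-fold higher number from compound 2 to compound 3 (0.52 log units; beyond the scatter) was at least modest, whereas the step that the two limits leave unreadable from compound 1 to compound 3 cannot be read from two limits.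

Compound 4 `O=C(O)c1cc(-c2ncc[nH]2)ccc1O` brings the next change: 1H-imidazol-2-yl in place of 1,3-thiazol-2-yl on an aromatic carbon. The nearest guide is an at least 3.3-fold higher number from compound 2 to compound 3 (0.52 log units; beyond the scatter) taken in reverse, which would point to a lower number; yet compound 1, whose ring also carries a hydrogen-bond donor, stayed at the limit, and an at least 3.3-fold lower number from compound 1 to compound 2 (0.52 log units; beyond the scatter) shows how much the imidazole of compound 2 gained. Compound 4 is therefore expected to give roughly 150 mg/kg, between 50 mg/kg and 400 mg/kg, an expected step of an at least 1.6-fold lower number from compound 3 to compound 4 (0.22 log units; that floor lies within the scatter).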

Compound 4, dose for half-maximal effect: 200 mg/kg
Compound 4: middle estimate off by 1.3-fold (0.12 log units), on the low side, within the range that was stated.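

In this assay, an imidazole alone does not settle the outcome: 1H-imidazol-2-yl in place of 1H-imidazol-1-yl gives a 2.7-fold higher number from compound 2 to compound 4 (0.43 log units; beyond the scatter), so the way this ring is attached to the shared core matters. Against the thiazole and the pyrazole, the new ring gives an at least 1.2-fold lower number from compound 3 to compound 4 (0.09 log units; that floor lies within the scatter) and an at least 1.2-fold lower number from compound 1 to compound 4 (0.09 log units; that floor lies within the scatter), and neither floor is enough to show a real gain. The values of compound 1 and compound 3 are only limits, not numbers: the limit of > 250 mg/kg in this assay, at which 2 of the 4 values shown sit.

Going by these compounds, what a methyl group or an amine on the imidazole of compound 2 would do to the dose stays open. Every compound shown also carries the same carboxy and hydroxy groups, so the effect of replacing the carboxy group with an amide is open as well.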